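Swapping cyano for trifluoromethyl on two anilide cores

The source may report more compounds than this note shows. Statements on the series, on what has been measured and on what is new or still open speak of the compounds shown alone.

The account begins with compound 1 `N#Cc1cccc(NC(=O)c2cc(F)ccc2O)c1`, which in a functional assay on HL-60 cells (Homo sapiens) for cytotoxicity, read by luminescence and CellTiter-Glo, with a stated time of 3 days (a lower number here means a stronger inhibitor, a higher number a weaker inhibitor), gives 7750 nM. Compound 3 `O=C(Nc1cccc(C(F)(F)F)c1)c1cc(F)ccc1O` carries the change trifluoromethyl in place of cyano on an aromatic carbon and gives 970 nM, so that an 8.0-fold lower number from compound 1 to compound 3 (0.90 log units; beyond the scatter). Compound 2 `N#Cc1ccc(NC(=O)c2ccc3cccnc3c2O)cc1` rests on a different core, and the difference between the two cores is not broken down here; in this assay compound 2 gives 370 nM, the lowest of the three numbers. Compound 4 `O=C(Nc1ccc(C(F)(F)F)cc1)c1ccc2cccnc2c1O`, not yet measured, applies the same kind of change to compound 2, namely (trifluoromethyl in place of cyano on an aromatic carbon), but the place differs: meta to a large group in the first pair, para to a large group here. On the strength of the step from compound 1 to compound 3, a smaller step is expected, a 2.8-fold lower number from compound 2 to compound 4 (0.45 log units; beyond the scatter), since the core and place differ. Compound 4 is therefore estimated at 130 nM, expected between 45 nM and 400 nM.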

Compound 4, half-maximal inhibitory concentration: 680 nM
Estimate against measurement, compound 4: 5.2-fold (0.72 log units) below, outside the stated range (above it).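

In this assay, within the data shown here, the swap of cyano for trifluoromethyl on the core of compound 2 gives a 1.8-fold higher number from compound 2 to compound 4 (0.26 log units; within the scatter) and so leaves no step that stands clear of the scatter. The swap thus did not carry over from the core of compound 1 to the core of compound 2 with the same size: the same change on two cores in this assay, an 8.0-fold lower number (0.90 log units; beyond the scatter) from compound 1 to compound 3 and a 1.8-fold higher number (0.26 log units; within the scatter) from compound 2 to compound 4, 15-fold (1.17 log units) apart, beyond the scatter of two such steps

This does not show what sets the two steps apart, since the two pairs differ in the core and also in the place of the group on the ring, and four compounds cannot separate the two.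

The compounds shown leave open how each core would respond if the group stood at the other place. They also leave open whether an amine or a carboxylic acid on the same aromatic carbon would track across the two cores.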